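A few compounds are considered here, and "the series" means these few. Any claim that something is new, unique, unknown or untested is made for them only; others in the source may bear on it.

In a functional assay on T98G cells (Homo sapiens) for inhibition, read by MTT assay, with a stated time of 72 h (on this read-out lower numbers stand for stronger inhibition and higher numbers for weaker inhibition), compound 1 `CC1(C)CC(NC(=S)Nc2cccc(Cl)c2)c2cc(Br)ccc2O1` gives 9000 nM and compound 2 `CC1(C)CC(NC(=S)Nc2ccc(Cl)cc2)c2cc(Br)ccc2O1` gives 22000 nM. Compound 2 therefore has the higher of the two numbers, which means the weaker inhibition. Within the data shown here, the single measured step is a 2.4-fold higher number from compound 1 to compound 2 (0.39 log units; beyond the scatter), with 4-chlorophenyl in place of 3-chlorophenyl. Compound 3 `CC1(C)CC(NC(=S)Nc2ccc(C#N)cc2)c2cc(Br)ccc2O1` keeps the rest of compound 2 and changes one group: cyano in place of chloro on an aromatic carbon. This is cyano in place of chloro on an aromatic carbon, para to a large group. Among the measured compounds shown here, no measured compound carries cyano, so the measured step bears on this change only indirectly: it shows a modest response to altering the chlorophenyl group, and it gives no direction. The expected result is a 1.2-fold lower number from compound 2 to compound 3 (0.09 log units; within the scatter), so no change beyond the scatter is anticipated. For compound 3 the estimated value in this assay is 18000 nM, with an expected range from 7000 nM to 45000 nM.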

Compound 3, half-maximal inhibitory concentration: 24000 nM
For compound 3 the middle estimate is 1.3-fold (0.12 log units) below the measured one; the range from low to high includes it.
By their numbers in this assay, from the lowest: compound 1; then compounds 2 and 3 (each within the scatter of the next).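

In this assay, among these compounds, cyano in place of chloro on an aromatic carbon, para to a large group, gives a 1.1-fold higher number from compound 2 to compound 3 (0.04 log units; within the scatter) and shows for the first time how a group other than chloro reads at this position: the two cannot be told apart here. The other new comparison, a 2.7-fold higher number from compound 1 to compound 3 (0.43 log units; beyond the scatter), is modest, and compound 1 keeps the lowest number of the three, so the 3-chlorophenyl group stands apart from both the 4-chlorophenyl and the 4-cyanophenyl groups. Nothing available explains why chloro and cyano read alike at this position.

An amine, a methoxy group or a carboxylic acid at this position could read like these two groups or quite differently. From the compounds shown here alone, it also remains open whether cyano would match compound 1 if it stood where the chloro of that compound stands.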